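Cyclopropylcarbonyl to Methoxycarbonyl: an Expected Value

The compounds below may be only part of what the source reports. "The series", "measured", "known", "first", "only" and "open" are said of these compounds alone.

Compound 1 `C[C@H]1CN(C(=O)c2ccco2)c2cc(-c3ccc(S(C)(=O)=O)cc3)ccc2N1C(=O)C1CC1` was tested in an ADME assay on microsomes from liver (Mus musculus) for metabolic stability, with a stated time of 30 min (a higher number here means that more of the compound is left, a lower number that less of the compound is left), where compound 1 gives 19%. Of the two numbers shown, that of compound 1 is the higher, but only by a gap that stays within the scatter. Its nearest neighbour is compound 2 `CCC(=O)N1c2ccc(-c3ccc(S(C)(=O)=O)cc3)cc2N(C(=O)c2ccco2)C[C@@H]1C`, which in this assay gives 11%. Among the compounds with values here, the one step between them, a number 8 percentage points lower from compound 1 to compound 2 (within the scatter), with ethyl in place of cyclopropyl on a carbonyl carbon, is small. Compound 3 `COC(=O)N1c2ccc(-c3ccc(S(C)(=O)=O)cc3)cc2N(C(=O)c2ccco2)C[C@@H]1C` has not yet been measured. It differs from compound 1 by methoxy in place of cyclopropyl on a carbonyl carbon, on a carbonyl carbon whose other neighbour is an amide-type nitrogen in a ring. Within the data shown here, the only measured step at that carbon bears on it and was small, so the expected step from compound 1 to compound 3 is none beyond the scatter, written as a number 4 percentage points lower from compound 1 to compound 3 (within the scatter). The estimate for compound 3 in this assay is accordingly 15%, with a range from 5% to 30%.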

Compound 3, percent of the compound remaining: 14%
Estimate against measurement, compound 3: 1 percentage points above; the measured number falls inside the stated range.
By their numbers in this assay, from the lowest: compounds 2, 3 and 1 (each within the scatter of the next).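

At the carbonyl carbon whose other neighbour is an amide-type nitrogen in a ring, this assay shows a number 5 percentage points lower from compound 1 to compound 3 (within the scatter) and also a number 3 percentage points higher from compound 2 to compound 3 (within the scatter) for methoxy in place of ethyl. Within the data shown here, the earlier compounds had compared only two groups made of carbon alone, whereas this change removes a three-membered ring and brings in oxygen with one hydrogen-bond acceptor, and still the three compounds remain within the scatter of one another. Nothing available explains why these groups do not separate in this read-out.

Going by these compounds, whether an amine such as dimethylamino or a longer chain on this carbonyl carbon would give a step beyond the scatter stays open. So does whether any group at this place can separate compounds on this core in this assay at all.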